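Inverting one stereocentre of compound 2

This account rests on a few compounds, and the source may have more. Where it says the series, first, only, none or still open, it means among the compounds named here.

In a functional assay on SW480 cells (Homo sapiens) for antiproliferative activity, read by MTT assay, with a stated time of 48 h (a lower number here means a stronger inhibitor, a higher number a weaker inhibitor), compound 1 `CC(C)=CCC[C@]1(C)/C=C/[C@@H](OC(=O)C=C(C)C)[C@](C)(O)/C=C/[C@H](O)/C(CO)=C\C1` gives > 40000 nM, which is a limit of the assay and not a number. Among the compounds with values here, compound 2 `CO[C@@H]1/C=C/[C@@](C)(O)[C@H](OC(=O)C=C(C)C)/C=C/[C@@](C)(CCC=C(C)C)C/C=C\1CO` gives 12800 nM, the only actual number so far. Compound 3 `CO[C@H]1/C=C/[C@@](C)(O)[C@H](OC(=O)C=C(C)C)/C=C/[C@@](C)(CCC=C(C)C)C/C=C\1CO` departs from compound 2 by the two compounds have the same atoms and bonds and differ only in configuration as drawn: 1 of 7 stereo elements differ; a stereocentre at a saturated ring carbon is drawn R in compound 2 and S in compound 3. Within the data shown here, no measured step isolates such an inversion, so no shift beyond the scatter in this assay is expected, in either direction. The expected step is small, a 1.2-fold higher number from compound 2 to compound 3 (0.07 log units; within the scatter). For compound 3 the estimated value is 15000 nM, with an expected range of 6000 nM to 40000 nM.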

Compound 3, half-maximal inhibitory concentration: 16600 nM
Compound 3: middle estimate off by 1.1-fold (0.04 log units), on the low side, within the range that was stated.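

In this assay, inverting a stereocentre at a saturated ring carbon gives a 1.3-fold higher number from compound 2 to compound 3 (0.11 log units; within the scatter), a read of configuration alone: the fact that compounds 2 and 3 differ only in the configuration as drawn

Methyl in place of hydrogen on an oxygen on a saturated carbon gives an at least 2.4-fold lower number from compound 1 to compound 3 (0.38 log units; beyond the scatter). Compound 1 gives > 40000 nM, a limit of the assay and not a number.

Left open is whether an ethyl or benzyl ether on that oxygen, or an amine in its place, gives a step beyond the scatter. Also open, going by these compounds, is whether the same inversion gives a step of similar size with the free hydroxyl of compound 1.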